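The compounds below may be only part of what the source reports. "The series", "measured", "known", "first", "only" and "open" are said of these compounds alone.

Measured so far:
- compound 1, `C=CCOC(=O)Nc1ccc([Se]C#N)cc1`: 27000 nM
- compound 2, `O=C(Nc1ccc([Se][Se]c2ccc(NC(=O)Oc3ccc(F)cc3)cc2)cc1)Oc1ccc(F)cc1`: 26700 nM

Working notes on the series. Of the compounds shown here, two have been tested in a functional assay on HTB-54 cells (Homo sapiens) for cytotoxicity, read by MTT assay, with a stated time of 72 h; a higher number here means a weaker inhibitor of growth, a lower number a stronger inhibitor of growth. Compound 1, the allyl carbamate bearing a selenocyanate, gives 27000 nM in this assay. Compound 2, the diselenide carrying fluorophenyl carbamates, gives 26700 nM in this assay. Compound 1 holds the higher of the two numbers, but its gap to compound 2 lies within the scatter of the measurement, so the two values are read as the same.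

The next compound, compound 3, `N#C[Se]c1ccc(NC(=O)Oc2ccccc2)cc1`, has not yet been measured. Relative to compound 1 it shows this change: phenyl in place of allyl on an oxygen next to a carbonyl group. Among the compounds with values here, no measured pair in the set covers this move, so there is no step to lean on. What is known is that compound 2, an aryl carbamate, sits where compound 1 sits, which argues against a large shift in either direction.

The step from compound 1 to compound 3 is therefore expected to be small, a 1.2-fold lower number from compound 1 to compound 3 (0.09 log units; within the scatter), not clearly beyond the scatter. Compound 3 is estimated at 22000 nM in this assay, in the range 7000 nM to 65000 nM.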

Compound 3, concentration for 50% growth inhibition: 26200 nM
Compound 3: middle estimate off by 1.2-fold (0.08 log units), on the low side; measured number inside the range.
By their numbers in this assay, from the lowest: compounds 3, 2 and 1 (each within the scatter of the next).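

In this assay, within the data shown here, phenyl in place of allyl on an oxygen next to a carbonyl group gives a 1.0-fold lower number from compound 1 to compound 3 (0.01 log units; within the scatter) and is the first step that can be read at this position. The earlier compounds shown here differed in more than one place and could not isolate this change. The step shows that, with the rest of compound 1 kept, going from 3 to 6 heavy atoms, gaining a six-membered aromatic ring and losing the double bond outside aromatic rings leaves the number within the scatter, although nothing at hand explains this result.

Among these compounds, whether an amine, a carboxylic acid or a longer carbon chain on this oxygen would move the number beyond the scatter remains open, since allyl and phenyl are the only two groups compared here in a single-place change. Going by these compounds, the contribution of the selenocyanate against the diselenide also remains open, as compound 2 differs from compound 1 and from compound 3 in more than one place.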